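One methoxy group added to compound 1

The source may hold more compounds than are shown below. What is called first, only, known or untested is meant among the compounds shown, and "the series" means these compounds.

In a functional assay on T98G cells (Homo sapiens) for inhibition, read by MTT assay, with a stated time of 72 h (a higher number here means a weaker inhibitor, a lower number a stronger inhibitor), compound 1 (`O=[N+]([O-])c1ccc(NC(=S)NCc2cccc(Cl)c2)cc1`) gives 20000 nM, and compound 2 (`CC1(C)CC(NC(=O)Nc2ccccc2)c2cc(Cl)ccc2O1`) gives 34000 nM. Among the compounds with values here, these two numbers lie within the usual scatter of each other, so this assay does not separate them, and compound 1 stands level with the only other measured compound.

The next compound to be tested is compound 3 (`COc1ccc(Cl)cc1CNC(=S)Nc1ccc([N+](=O)[O-])cc1`), which keeps the core of compound 1 and carries one change: methoxy in place of hydrogen on an aromatic carbon. In words, this is methoxy in place of hydrogen on an aromatic carbon, ortho to a large group and para to a chloro group.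

Within the data shown here, no measured pair of compounds isolates a single change, so the data offer no direct guide to the effect of this one. With nothing to suggest a direction, the safest expectation is a small change. The estimated step of a 1.2-fold lower number from compound 1 to compound 3 (0.07 log units; within the scatter) is expected to stay within the usual scatter. For compound 3 the estimated value in this assay is 17000 nM, with an expected range from 6000 nM to 45000 nM.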

Compound 3, half-maximal inhibitory concentration: 35000 nM
Estimate against measurement, compound 3: 2.1-fold (0.31 log units) below; the range from low to high includes it.
By their numbers in this assay, from the lowest: compounds 1, 2 and 3 (each within the scatter of the next).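

Within the data shown here, this is the first pair of compounds that differ in one place, so it gives the first direct reading of any single change. In this assay, methoxy in place of hydrogen on an aromatic carbon, ortho to a large group and para to a chloro group, gives a 1.8-fold higher number from compound 1 to compound 3 (0.24 log units; within the scatter), so at this position the assay does not separate the methoxy compound from the parent that carries only hydrogen there, and the added oxygen and carbon leave no mark that can be told from the ordinary spread of repeated measurements. No measured information on these compounds speaks to what lies behind this result.

This single pair says nothing about how other groups would behave on the same aromatic carbon, so an amine, a hydroxyl group or a longer chain such as ethoxy could still give a step beyond the scatter. It also leaves open whether methoxy would read the same way on the other carbons of that ring, since one position and one group are all that this comparison covers.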